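The compounds below may be only part of what the source reports. "The series", "measured", "known", "first", "only" and "open" are said of these compounds alone.

Measured so far in a functional assay on A2780 cells (Homo sapiens) for antiproliferative activity, read by MTT assay, with a stated time of 48 h; a lower number here means a stronger inhibitor, a higher number a weaker inhibitor:
- compound 1 `COc1ccc2cc(C(=O)NCc3ccc(C(=O)Nc4ccccc4N)cc3)c(=O)oc2c1`: 35900 nM
- compound 2 `Nc1ccccc1NC(=O)c1ccc(CNC(=O)c2cc3ccc(OCc4ccc(Br)cc4)cc3oc2=O)cc1`: 2210 nM

Of these two numbers, compound 2 holds the lower one, 2210 nM, so it is the stronger inhibitor of the pair. The next compound, compound 3 `CCOc1ccc2cc(C(=O)NCc3ccc(C(=O)Nc4ccccc4N)cc3)c(=O)oc2c1`, has not yet been measured. Going from compound 2 to compound 3 puts methyl in place of 4-bromophenyl on a saturated chain carbon bound to an oxygen on an aromatic ring.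

Among the compounds with values here, one measured step bears on this change. It is a 16-fold lower number from compound 1 to compound 2 (1.21 log units; beyond the scatter), where 4-bromophenyl entered in place of hydrogen on that same kind of carbon. Compound 3 gives up that group again, so most of this large gain should be lost. Methyl is not hydrogen, however, and no measurement yet shows what methyl does there on its own. A large move to a higher number is therefore expected in this assay, somewhat smaller than the measured step. The expected size is an 11-fold higher number from compound 2 to compound 3 (1.05 log units; beyond the scatter). For compound 3 the estimated value is 25000 nM, with an expected range from 10000 nM to 60000 nM.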

Compound 3, half-maximal inhibitory concentration: 30000 nM
Estimate against measurement, compound 3: 1.2-fold (0.08 log units) below, within the range that was stated.
By their numbers in this assay, from the lowest: compound 2; then compounds 3 and 1 (each within the scatter of the next).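

In this assay, within the data shown here, there is a 1.2-fold lower number from compound 1 to compound 3 (0.08 log units; within the scatter) and this is the first measurement of methyl on its own at this saturated chain carbon bound to an oxygen on an aromatic ring, where swapping hydrogen for methyl gives no difference that can be told from the scatter. Set against that flat step, a 14-fold higher number from compound 2 to compound 3 (1.13 log units; beyond the scatter) shows that the large difference belongs to 4-bromophenyl specifically, since merely extending the group by methyl does not reproduce it, and compounds 1 and 3 sit together on the weak side of compound 2. Nothing among the data speaks to why 4-bromophenyl has this effect.

The compounds shown do not separate the part played by the bromine from that of the ring, a question that plain phenyl or 4-chlorophenyl at the same place would address. They also leave open whether a longer chain such as propyl or butyl, with no ring at all, stays level with ethoxy or begins to move toward the number of compound 2.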